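A few compounds are considered here, and "the series" means these few. Any claim that something is new, unique, unknown or untested is made for them only; others in the source may bear on it.

Compound 3 `COc1cc(N2CCNCC2)c2c(c1)N(S(=O)(=O)c1ccccc1F)CCO2` gives the lowest number of the three measured in an assay on HEK293 cells for displacement of a labelled ligand from 5-hydroxytryptamine receptor 6 (Homo sapiens) (a higher number here means a weaker inhibitor, a lower number a stronger inhibitor), at 0.159 nM. Compound 1 `Cc1cc(N2CCNCC2)c2c(c1)N(S(=O)(=O)c1ccccc1F)CCO2` gives 0.398 nM in this assay, and compound 2 `O=S(=O)(c1ccccc1F)N1CCOc2c(N3CCNCC3)cc(F)cc21` gives 0.631 nM. Compound 4 `CC(C)(C)c1cc(N2CCNCC2)c2c(c1)N(S(=O)(=O)c1ccccc1F)CCO2` differs from compound 3 by tert-butyl in place of methoxy on an aromatic carbon. Going by the values given here, two measured steps bear on this change: a 2.5-fold lower number from compound 1 to compound 3 (0.40 log units; beyond the scatter) and a 4.0-fold lower number from compound 2 to compound 3 (0.60 log units; beyond the scatter), both showing the methoxy group giving the lower number, while a 1.6-fold higher number from compound 1 to compound 2 (0.20 log units; within the scatter). Among the compounds with values here, no measured step shows tert-butyl itself. With the methoxy group gone, the expected step is a 5.0-fold higher number from compound 3 to compound 4 (0.70 log units; beyond the scatter), back toward the number of compound 1, with a wide range to cover the untested group. Compound 4 is therefore expected at 0.8 nM, with a range from 0.25 nM to 2.5 nM.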

Compound 4, inhibition constant: 7.94 nM
Estimate against measurement, compound 4: 9.9-fold (1.00 log units) below; the measured number lies above the stated range.
By their numbers in this assay, from the lowest: compound 3; then compounds 1 and 2 (each within the scatter of the next); then compound 4.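

Tert-butyl is the first group at this position, on an aromatic carbon meta to a piperazin-1-yl group, to move the number in this assay by a large step, with a 50-fold higher number from compound 3 to compound 4 (1.70 log units; beyond the scatter) and a 20-fold higher number from compound 1 to compound 4 (1.30 log units; beyond the scatter) and a 13-fold higher number from compound 2 to compound 4 (1.10 log units; beyond the scatter) set against the smaller steps among methoxy, methyl and fluoro. The position therefore accepts those three groups with little change but not this one. No evidence is at hand to explain the size of these steps. The compounds shown leave open how an isopropyl or ethoxy group would read at this position, and so whether the number climbs gradually with group size or jumps only at tert-butyl.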